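Compound 3 to compound 4: a ring-free side chain

This account rests on a few compounds, and the source may have more. Where it says the series, first, only, none or still open, it means among the compounds named here.

In a functional assay on MCF7 cells (Homo sapiens) for cytotoxicity, read by MTT assay, with a stated time of 72 h (on this read-out higher numbers stand for weaker inhibition and lower numbers for stronger inhibition), compound 1 `O=C1c2c[n+]([O-])c3ccccc3c2C(=O)c2c1c1ccccc1n2Cc1cn([C@H]2O[C@H](CO)[C@@H](O)[C@H]2O)nn1` gives 1490 nM, compound 2 `CC1(C)OC[C@H](Cn2cc(Cn3c4c(c5ccccc53)C(=O)c3c[n+]([O-])c5ccccc5c3C4=O)nn2)O1` gives 530 nM and compound 3 `O=C1c2c[n+]([O-])c3ccccc3c2C(=O)c2c1c1ccccc1n2Cc1cn([C@H]2C[C@H](O)[C@@H](CO)O2)nn1` gives 530 nM. Compound 3 is thus level with compound 2, and together they hold the lowest of the three numbers. Compound 4 `O=C1c2c[n+]([O-])c3ccccc3c2C(=O)c2c1c1ccccc1n2Cc1cn(C[C@@H](O)CO)nn1` carries 2,3-dihydroxypropyl in place of 4-hydroxy-5-(hydroxymethyl)oxolan-2-yl on an aromatic nitrogen. The measured steps at this same place are a 2.8-fold lower number from compound 1 to compound 2 (0.45 log units; beyond the scatter), a 2.8-fold lower number from compound 1 to compound 3 (0.45 log units; beyond the scatter) and no change at the digits printed from compound 2 to compound 3 (within the scatter). None exceeds a modest size, so only a small move is expected, slightly upward if any. The estimated step is a 1.3-fold higher number from compound 3 to compound 4 (0.12 log units; within the scatter). For compound 4 the estimated value is 700 nM, with an expected range of 300 nM to 1600 nM.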

Compound 4, half-maximal inhibitory concentration: 600 nM
The estimate for compound 4 lay 1.2-fold (0.07 log units) above the measured number, within the range that was stated.
By their numbers in this assay, from the lowest: compounds 2, 3 and 4 (each within the scatter of the next); then compound 1.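

In this assay, a ring-free side chain reads like the ring it replaces, with a 1.1-fold higher number from compound 3 to compound 4 (0.05 log units; within the scatter), so at this aromatic nitrogen 2,3-dihydroxypropyl keeps the level without the five-membered ring. The 1,2-dihydroxyethyl end also matches 2,2-dimethyl-1,3-dioxolan-4-yl on the saturated chain carbon, with a 1.1-fold higher number from compound 2 to compound 4 (0.05 log units; within the scatter). Compound 1 remains apart, with a 2.5-fold lower number from compound 1 to compound 4 (0.40 log units; beyond the scatter), so only 3,4-dihydroxy-5-(hydroxymethyl)oxolan-2-yl separates from the other groups here.

Nothing available explains these readings. As far as these compounds go, whether an amine, a carboxylic acid or a longer chain at this nitrogen would hold this level remains open.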